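A few compounds are considered here, and "the series" means these few. Any claim that something is new, unique, unknown or untested is made for them only; others in the source may bear on it.

Three members of the series carry the shared core with an aromatic group next to the ring sulfur, and none of them shows measurable displacement. Compound 1 `CC(C)(C)Cc1c(-c2ccc(F)cc2F)sc(N)c1C(=O)c1ccc(Cl)cc1` gives 1% in an assay on CHO cells for displacement of a labelled ligand from adenosine receptor A3 (Homo sapiens), read by scintillation counting, tested at 10 uM; a higher number here means more inhibition at the concentration tested (going by the name of the read-out), a lower number less inhibition. Compound 2 `COc1cccc(-c2sc(N)c(C(=O)c3ccc(Cl)cc3)c2CC(C)(C)C)c1` gives 1% in this assay, and compound 3 `Cc1ccc(-c2sc(N)c(C(=O)c3ccc(Cl)cc3)c2CC(C)(C)C)cc1` gives 1% in this assay. The steps among them are flat: no change at the digits printed from compound 1 to compound 2 (within the scatter), no change at the digits printed from compound 1 to compound 3 (within the scatter) and no change at the digits printed from compound 2 to compound 3 (within the scatter). Compound 3 therefore stands level with compounds 1 and 2 at the digits shown, with compound 1 nearest and compound 2 furthest only nominally, since all three values coincide.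

Compound 4 `CC(C)(C)Cc1c(-c2cn[nH]c2)sc(N)c1C(=O)c1ccc(Cl)cc1` takes the step (1H-pyrazol-4-yl in place of 4-methylphenyl on an aromatic carbon). Going by the values given here, no measured step bears directly on this exchange: the three measured steps each swap one six-membered aromatic ring of carbon only for another of the same kind and all stay within the scatter, whereas here a five-membered aromatic ring with a hydrogen-bond donor and acceptor enters. Exchanges of the aromatic group have so far moved nothing in this assay, so the expected step is a number 2 percentage points higher from compound 3 to compound 4 (within the scatter), none beyond the scatter. Compound 4 is accordingly estimated at 3% in this assay. The expected range for compound 4 runs from -8% to 20%.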

Compound 4, a percentage reported as inhibition, at one concentration (the size of the read-out at that concentration, not a potency): 1%
Compound 4: middle estimate off by 2 percentage points, on the high side; low and high end bracket the measured number.
By their numbers in this assay, from the lowest: compounds 1, 2, 3 and 4 (each within the scatter of the next).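

Placing 1H-pyrazol-4-yl on the aromatic carbon next to the ring sulfur brings in a five-membered aromatic ring with 2 hetero atoms, 1 hydrogen-bond donor and 1 hydrogen-bond acceptor, and this assay shows no change at the digits printed from compound 3 to compound 4 (within the scatter) and no change at the digits printed from compound 2 to compound 4 (within the scatter) and also no change at the digits printed from compound 1 to compound 4 (within the scatter) for this exchange. The flat picture at this position therefore no longer rests only on six-membered aromatic rings of carbon only, and it now also covers a group with hetero atoms, a hydrogen-bond donor and a hydrogen-bond acceptor. Nothing available accounts for this flat read-out.

As far as these compounds go, all four compounds share the neopentyl group, the (4-chlorophenyl)carbonyl group and the amino group, so it remains open whether any of these three places governs displacement in this assay and whether a benzyl group in place of neopentyl would give a different reading. From the compounds shown here alone, it also remains open whether a non-aromatic group at the position next to the ring sulfur, such as a carboxylic acid or a piperidine, would lift the value above the level shared by these compounds.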